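The source may report more compounds than this note shows. Statements on the series, on what has been measured and on what is new or still open speak of the compounds shown alone.

Measured so far:

Compound 1, `Cc1ccc(Oc2ccc3nc(COc4cccc(C(=O)O)c4)n(C)c3n2)c(C)c1`, gives 28.8 10^-6 cm/s in an ADME assay for permeability, using PAMPA, with a stated time of 4 h; on this read-out lower numbers stand for lower permeability and higher numbers for higher permeability.
Compound 2, `Cc1ccc(Oc2cc3c(cn2)nc(COc2cccc(C(=O)O)c2)n3C)cc1`, gives 6.8 10^-6 cm/s in this assay.
Compound 3, `Cn1c(COc2cccc(C(=O)O)c2)nc2ccc(Oc3ccccn3)cc21`, gives 2.2 10^-6 cm/s in this assay.

Of these three numbers compound 3 stands lowest. The nearest to it is compound 2, whose number is higher by a gap beyond the usual scatter; compound 1 is furthest away, higher again by a gap well beyond the scatter. No two of these compounds differ in only one place, so their values can only be set side by side, and nothing can be said about what any single change did.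

The next compound, compound 4, `Cc1cc(Cl)cnc1Oc1ccc2nc(COc3cccc(C(=O)O)c3)n(C)c2c1`, has not yet been measured in this assay. It differs from compound 3 in one place: 5-chloro-3-methylpyridin-2-yl in place of pyridin-2-yl on an oxygen on an aromatic ring. The group that enters is the larger of the two by the count given, and the rest of the molecule is unchanged.

For the measured compounds named here, with no matched step to lean on, the direction of the change is a guess. Because compound 1 gives 28.8 10^-6 cm/s and compound 2 gives 6.8 10^-6 cm/s, both above compound 3, compounds carrying a more substituted ring on that oxygen have so far read higher, although their cores differ too. A moderate rise, beyond the scatter but not large, is therefore expected: the step from compound 3 to compound 4 is estimated at a 2.5-fold higher number from compound 3 to compound 4 (0.40 log units; beyond the scatter). For compound 4 the expected value in this assay is 5.5 10^-6 cm/s, with a likely range from 2.2 10^-6 cm/s to 14 10^-6 cm/s.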

Compound 4, apparent permeability: 13.7 10^-6 cm/s
Estimate against measurement, compound 4: 2.5-fold (0.40 log units) below, within the range that was stated.
By their numbers in this assay, from the lowest: compound 3; then compounds 2 and 4 (each within the scatter of the next); then compound 1.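

At this position, on an oxygen on an aromatic ring, there is now a matched pair, meaning two compounds that differ in only one place, so a change can be followed directly: in this assay, 5-chloro-3-methylpyridin-2-yl in place of pyridin-2-yl gives a 6.2-fold higher number from compound 3 to compound 4 (0.79 log units; beyond the scatter) on this read-out. A swap confined to the group on that oxygen, with the rest of the molecule unchanged, is therefore enough to move the number past the usual scatter, and here the larger of the two groups carries the higher number. Nothing available explains the rise, so it stands as an observation without a known cause.

The chloro and the methyl group arrive together, so this single step cannot show how much of the rise belongs to each, and 5-chloropyridin-2-yl or 3-methylpyridin-2-yl alone on the same oxygen would be needed to separate them. On these data alone, whether a plain phenyl ring, or a pyridine ring carrying an amine or a methoxy group, would read the same way at this position also stays open.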